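The source may report more compounds than this note shows. Statements on the series, on what has been measured and on what is new or still open speak of the compounds shown alone.

Working notes on the series.

Three compounds have a number in a functional assay on K562 cells (Homo sapiens) for cytotoxicity, read by sulforhodamine B assay, with a stated time of 48 h, tested at 0.01 uM (on this read-out higher numbers stand for a weaker effect at the one concentration tested and lower numbers for a stronger effect), so far. Compound 1 `COc1cc(-c2cc(/C=C/C(=O)c3ccc(N)cc3)[nH]n2)cc(OC)c1OC` gives 100% in this assay. Compound 2 `COc1ccc(-c2cc(/C=C/C(=O)c3ccc(OC)c(OC)c3)[nH]n2)cc1` gives 109% in this assay. Compound 3 `COc1cc(-c2cc(/C=C/C(=O)c3ccc(Cl)c(Cl)c3)[nH]n2)cc(OC)c1OC` gives 99% in this assay. Compound 3 thus sits in one band with the other two: its gap to compound 1 and its gap to compound 2 both fall within the usual scatter, so no order among the three can be read from these numbers. For the measured compounds named here, the one single-point step measured, a number 1 percentage points lower from compound 1 to compound 3 (within the scatter), shows that swapping the ring on the carbonyl carbon left the read-out unchanged.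

The next compound, compound 4 `COc1ccc(C(=O)/C=C/c2cc(-c3cc(OC)c(OC)c(OC)c3)n[nH]2)cc1OC`, differs from compound 3 at that same carbonyl carbon: 3,4-dimethoxyphenyl in place of 3,4-dichlorophenyl on a carbonyl carbon. Going by the values given here, the step from compound 1 to compound 3 is the only measured step bearing on this position, and it was within the scatter. Compound 2 also carries a 3,4-dimethoxyphenyl on its carbonyl carbon, though with a different group on the shared core, and its value of 109% sits in the same band as the rest. No change beyond the scatter is therefore expected in this assay, and the estimated step is a number 4 percentage points higher from compound 3 to compound 4 (within the scatter). For compound 4 the expected read-out is 103%, with a range from 92% to 115%.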

Compound 4, a percentage reported as activity, at one concentration (the size of the read-out at that concentration, not a potency): 96%
Beside the measured number, compound 4's estimate is 7 percentage points above it; the measured number falls inside the stated range.
By their numbers in this assay, from the lowest: compounds 4, 3, 1 and 2 (each within the scatter of the next, the first and the last beyond it).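

With a number 3 percentage points lower from compound 3 to compound 4 (within the scatter) and a number 4 percentage points lower from compound 1 to compound 4 (within the scatter), the position on the carbonyl carbon has now held three different rings on one shared core in this assay, and none of the steps between them leaves the scatter. For the compounds shown here, until now, 3,4-dimethoxyphenyl had been seen only in compound 2, with a different group on the shared core; compound 4 places it on the same core as compound 1 and compound 3, and this change, from 0 to 2 hydrogen-bond acceptors and from 8 to 10 heavy atoms, does not separate compound 4 from compound 3 on this read-out. No measurement at hand offers an explanation for this flat result.

The compounds shown cover only six-membered aromatic rings of carbon at this position, so it remains open whether a group of another kind on the carbonyl carbon, such as a carboxylic acid or a longer chain, would give a step beyond the scatter. With one concentration and all three steps within the scatter, the read-out gives no order among 4-aminophenyl, 3,4-dichlorophenyl and 3,4-dimethoxyphenyl, and it gives no potency for any of them.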